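The compounds below may be only part of what the source reports. "The series", "measured", "known", "first", "only" and "open" are said of these compounds alone.

In an ADME assay on MT4 cells (Homo sapiens) for cytotoxicity, read by MTT assay (a lower number here means that less compound is tolerated, a higher number that more compound is tolerated), three compounds have been measured:
compound 1 `Cc1ccc(-c2c(C)nc(C(=O)N(C)Cc3ccccc3)c(C)c2C(OC(C)(C)C)C(=O)O)cc1C` gives 77000 nM;
compound 2 `Cc1ccc(-c2c(C)nc(Nc3nc4ccccc4n3C)c(C)c2C(OC(C)(C)C)C(=O)O)cc1C` gives 14000 nM;
compound 3 `Cc1ccc(-c2c(C)nc(NC(=O)NC3CCCCCC3)c(C)c2C(OC(C)(C)C)C(=O)O)cc1C` gives 7700 nM.

Compound 3 carries the lowest of these three numbers. One gap lies within the scatter, a 1.8-fold lower number from compound 2 to compound 3 (0.26 log units; within the scatter), so those two cannot be told apart, whereas compound 1 sits clearly apart: a 10-fold lower number from compound 1 to compound 3 (1.00 log units; beyond the scatter). Compound 4 `Cc1ccc(-c2c(C)nc(Nc3nc4ccccc4s3)c(C)c2C(OC(C)(C)C)C(=O)O)cc1C` is reached by 1,3-benzothiazol-2-yl in place of cycloheptylcarbamoyl on a nitrogen on an aromatic ring. Among the measured compounds shown here, the one measured step that touches this position is a 1.8-fold lower number from compound 2 to compound 3 (0.26 log units; within the scatter), where cycloheptylcarbamoyl took the place of 1-methyl-1H-benzimidazol-2-yl on a nitrogen on an aromatic ring; compound 4 again carries a fused aromatic group there. No step beyond the scatter is therefore expected: a 1.4-fold higher number from compound 3 to compound 4 (0.15 log units; within the scatter). Compound 4 is estimated at 11000 nM, within 4500 nM to 28000 nM.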

Compound 4, half-maximal cytotoxic concentration: 6600 nM
Estimate against measurement, compound 4: 1.7-fold (0.22 log units) above; measured number inside the range.
By their numbers in this assay, from the lowest: compounds 4, 3 and 2 (each within the scatter of the next, the first and the last beyond it); then compound 1.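

In this assay, 1,3-benzothiazol-2-yl and cycloheptylcarbamoyl on this nitrogen cannot be told apart (a 1.2-fold lower number from compound 3 to compound 4 (0.07 log units; within the scatter)), although one is a fused aromatic group and the other a non-aromatic ring on a carbonyl. The two fused aromatic groups do separate, if only just (a 2.1-fold lower number from compound 2 to compound 4 (0.33 log units; beyond the scatter)). The (1,3-benzothiazol-2-yl)amino group also stays far from the benzyl(methyl)carbamoyl of compound 1 (a 12-fold lower number from compound 1 to compound 4 (1.07 log units; beyond the scatter)).

No measurement shown explains these differences. On these data alone, how a 1,3-benzoxazol-2-yl group or a plain methyl on this nitrogen would compare remains open.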